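Replacing the Methoxy(methyl)amino Group on a Shared Core

The source may report more compounds than this note shows. Statements on the series, on what has been measured and on what is new or still open speak of the compounds shown alone.

Compound 1, `Oc1ccc2oc(Cc3ccccc3)cc2c1CN1CCc2ccccc2C1`, gives 16000 nM in a functional assay on SQ20B cells (Homo sapiens) for cytotoxicity, read by MTT assay, with a stated time of 72 h; on this read-out higher numbers stand for weaker inhibition and lower numbers for stronger inhibition.
Compound 2, `CON(C)Cc1c(O)ccc2oc(Cc3ccccc3)cc12`, gives 40000 nM in this assay.
Compound 3, `Oc1ccc2oc(Cc3ccccc3)cc2c1CN1CCCC(O)C1`, gives 11000 nM in this assay.

Among these three, compound 2 stands at the highest number in this assay; compound 1 sits nearer to it with a lower number, and compound 3 lies furthest, also at a lower number. Compound 4, `NC(=O)C1CCN(Cc2c(O)ccc3oc(Cc4ccccc4)cc23)CC1`, has not yet been measured in this assay. It differs from compound 2 in a single place: 4-carbamoylpiperidin-1-yl in place of methoxy(methyl)amino on a saturated chain carbon bound to an aromatic carbon. Going by the values given here, one measured step bears directly on this change, a 3.6-fold lower number from compound 2 to compound 3 (0.56 log units; beyond the scatter), in which a differently substituted piperidin-1-yl also entered at the same position in place of methoxy(methyl)amino. Given that precedent, a modest downward step of comparable size is expected for compound 4, a 3.3-fold lower number from compound 2 to compound 4 (0.52 log units; beyond the scatter). On that basis the value of compound 4 in this assay is estimated at 12000 nM, with an expected range from 5000 nM to 30000 nM.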

Compound 4, half-maximal inhibitory concentration: 85000 nM
Beside the measured number, compound 4's estimate is 7.1-fold (0.85 log units) below it; the measured number lies above the stated range.
By their numbers in this assay, from the lowest: compounds 3 and 1 (each within the scatter of the next); then compound 2; then compound 4.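

At this saturated chain carbon bound to an aromatic carbon, putting a substituted piperidin-1-yl in place of methoxy(methyl)amino does not lower the number in every case: in this assay, 4-carbamoylpiperidin-1-yl gives a 2.1-fold higher number from compound 2 to compound 4 (0.33 log units; beyond the scatter), whereas 3-hydroxypiperidin-1-yl gave a 3.6-fold lower number from compound 2 to compound 3 (0.56 log units; beyond the scatter). The direction of the step therefore depends on which substituted piperidin-1-yl enters, and the two also stand well apart, with a 7.7-fold higher number from compound 3 to compound 4 (0.89 log units; beyond the scatter). Nothing measured here accounts for this reversal.

From the compounds shown here alone, it remains open which part of the exchange between the two piperidin-1-yl groups carries the rise, a question that 4-hydroxypiperidin-1-yl and 3-carbamoylpiperidin-1-yl at this carbon would separate. Where unsubstituted piperidin-1-yl or 4-carboxypiperidin-1-yl would stand on this read-out is equally open.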